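Third hydroxy on the aryl ring of compound 2

This account rests on a few compounds, and the source may have more. Where it says the series, first, only, none or still open, it means among the compounds named here.

Measured so far in a functional assay on MGC-803 cells (Homo sapiens) for inhibition, read by MTT assay; a higher number here means a weaker inhibitor, a lower number a stronger inhibitor:
- compound 1 `Cc1c(C(=O)N/N=C\c2cccc(O)c2O)oc2cccc(O)c12`: 5030 nM
- compound 2 `Cc1c(C(=O)N/N=C\c2ccc(O)cc2O)oc2cccc(O)c12`: 7330 nM

Among the compounds with values here, compound 2 is one of only two measured compounds, and its number and that of compound 1 lie within the scatter of each other: the step from compound 1 to compound 2 was a 1.5-fold higher number from compound 1 to compound 2 (0.16 log units; within the scatter). Compound 3 `Cc1c(C(=O)N/N=C\c2ccc(O)c(O)c2O)oc2cccc(O)c12` differs from compound 2 by hydroxy in place of hydrogen on an aromatic carbon. Within the data shown here, the single measured step that bears on this change is the exchange of one dihydroxyphenyl pattern for another between compound 1 and compound 2, and that step stayed within the scatter. Among the measured compounds shown here, nothing measured so far shows that altering the hydroxy pattern on this ring moves this assay beyond the scatter. For compound 3 in this assay a step of a 1.1-fold lower number from compound 2 to compound 3 (0.05 log units; within the scatter) is expected, that is, none beyond the scatter. Compound 3 is therefore estimated at 6500 nM, with a range from 2500 nM to 17000 nM.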

Compound 3, half-maximal inhibitory concentration: 18100 nM
For compound 3 the middle estimate is 2.8-fold (0.44 log units) below the measured one; measured number above the stated range.
By their numbers in this assay, from the lowest: compounds 1 and 2 (each within the scatter of the next); then compound 3.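

In this assay, within the data shown here, hydroxy in place of hydrogen on this aromatic carbon, ortho to two hydroxy groups, gives a 2.5-fold higher number from compound 2 to compound 3 (0.39 log units; beyond the scatter) and is the first step to pass the scatter. The comparison from the other dihydroxyphenyl compound gives a 3.6-fold higher number from compound 1 to compound 3 (0.56 log units; beyond the scatter) and points the same way, whereas the exchange between the two dihydroxyphenyl patterns stayed within the scatter. The hydroxy pattern on this ring can therefore move this read-out: among these three compounds, the one carrying the added hydroxy is the weakest inhibitor, though both steps are modest.

Open, from the compounds shown here alone, is whether this step belongs to hydroxy itself or to any substituent on this carbon; a methoxy group, a fluorine atom or an amine there would bear on that. Nothing available explains the step.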